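A small branching change, tested on two related cores

A few compounds are considered here, and "the series" means these few. Any claim that something is new, unique, unknown or untested is made for them only; others in the source may bear on it.

Compound 1 `CCCOC(=O)C1=C(C)N(C)C(=O)NC1c1cccs1` and compound 2 `CC1=C(C(=O)OCC(C)C)C(c2cccs2)NC(=O)N1C` share one core; compound 3 `CCSC(=O)C1=C(C)NC(=O)NC1c1ccco1` and compound 4 `CC1=C(C(=O)SC(C)C)C(c2ccco2)NC(=O)N1` share another, and the difference between the two cores is not broken down here. In an assay on membranes from HeLa cells for displacement of a labelled ligand from adenosine receptor A3 (Homo sapiens), read by scintillation counting, with a stated time of 180 min, tested at 1 uM (a lower number here means less inhibition, a higher number more inhibition at the concentration tested (going by the name of the read-out)), compound 1 gives 4%, compound 2 gives 5%, and compound 3 gives 14%. The change methyl in place of hydrogen on a saturated chain carbon bound to two saturated chain carbons gave a number 1 percentage points higher from compound 1 to compound 2 (within the scatter). Compound 4 carries the same kind of change, (methyl in place of hydrogen on a saturated chain carbon bound to a saturated chain carbon and a sulfur), though the place differs: there the carbon is bound to two saturated chain carbons, here to a saturated chain carbon and a sulfur. Because the step of a number 1 percentage points higher from compound 1 to compound 2 (within the scatter) stayed within the scatter, a step of no change at the digits printed from compound 3 to compound 4 (within the scatter) in this assay is expected here as well. Compound 4 is therefore estimated at 14%, within 3% to 26%.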

Compound 4, a percentage reported as inhibition, at one concentration (the size of the read-out at that concentration, not a potency): 1%
The estimate for compound 4 lay 13 percentage points above the measured number, outside the stated range (below it).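

In this assay the branching change gave a number 13 percentage points lower from compound 3 to compound 4 (beyond the scatter) while the earlier step on the other core stayed within the scatter. Set side by side, the two steps cannot be told apart: the same change on two cores in this assay, a number 1 percentage points higher (within the scatter) from compound 1 to compound 2 and a number 13 percentage points lower (beyond the scatter) from compound 3 to compound 4, 14 percentage points apart, within the scatter of two such steps. Going by these compounds alone, this does not show that the change behaves differently on the two cores, nor does it show that the change carries over unaltered, since there are only two pairs and the place of the change differs between them.

The compounds shown leave open whether a longer chain or an amine in place of the isopropylsulfanyl group would raise the number in this assay. They also leave open how the two cores themselves compare.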